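A few compounds are considered here, and "the series" means these few. Any claim that something is new, unique, unknown or untested is made for them only; others in the source may bear on it.

Compound 1, `C[C@@H](NC(=O)/C=C/c1ccc(C(C)(C)C)cc1)c1ccc(NS(C)(=O)=O)cc1`, in an assay on isolated protein for agonist activity at transient receptor potential cation channel subfamily V member 1 (Rattus norvegicus), read by scintillation counting and calcium flux, with a stated time of 10 min, in the presence of a further agent that is not named here (a lower number here means that less compound is needed, a higher number that more compound is needed for the effect), gives > 100000 nM, which is a limit of the assay rather than a number.
Compound 2, `C[C@@H](NC(=O)CCc1ccc(C(C)(C)C)cc1)c1ccc(NS(C)(=O)=O)cc1`, in this assay gives > 100000 nM, again a limit of the assay and not a number.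

Compound 2 therefore does not stand at any numbered point: both values shown here sit at the limit of > 100000 nM in this assay, at which 2 of the 2 values shown sit, and compound 2 is one of them. Within the data shown here, no measured pair here differs in only one place, so no step size between measured compounds is known. Compound 3, `CC(Cc1ccc(C(C)(C)C)cc1)C(=O)N[C@H](C)c1ccc(NS(C)(=O)=O)cc1`, differs from compound 2 by methyl in place of hydrogen on a saturated chain carbon bound to a carbonyl carbon and a saturated chain carbon. Among the measured compounds shown here, with no measured step to build on, the expectation for this assay is no change beyond the usual scatter, in either direction, because both measured compounds sit at the limit of > 100000 nM in this assay, at which 2 of the 2 values shown sit, and give nothing to extend. Compound 3 is therefore expected to give about 100000 nM, within 30000 nM to 300000 nM, and most likely to be reported once more only as a limit. The step of a number no higher from compound 2 to compound 3 (the limit leaves the size open) is estimated to be essentially none.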

Compound 3, half-maximal effective concentration: > 100000 nM
Compound 3 ended at the assay's limit; the forecaster's own chance of this, stated with the estimate: 80%; the middle value sits exactly at the limit.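

Compound 2 and compound 3 both end at a limit of this assay and not at a number, so no step can be read between them: the limit of > 100000 nM in this assay, at which 3 of the 3 values shown sit.

The compounds shown leave open whether methyl in place of hydrogen changes the concentration needed at all, and what concentration any of them would actually need.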